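Dienone series: naphthyl to thienyl swap at the enone terminus

The source may hold more compounds than are shown below. What is called first, only, known or untested is meant among the compounds shown, and "the series" means these compounds.

Measured compounds:
compound 1 `COc1cc(/C=C/C(=O)/C=C/c2cccc3ccccc23)ccc1OCc1cn(CCCOc2cc(=O)oc3ccccc23)nn1` — 66%
compound 2 `COc1ccc(/C=C/C(=O)/C=C/c2ccc(OCc3cn(CCCCCOc4cc(=O)oc5ccccc45)nn3)c(OC)c2)cc1OC` — 45%

Two compounds of this coumarin-triazole-dienone series have numbers in a functional assay on HCT-116 cells (Homo sapiens) for inhibition, read by sulforhodamine B assay, with a stated time of 48 h, tested at 50 uM; a lower number here means less inhibition of growth, a higher number more inhibition of growth at the concentration tested. Compound 1 gives 66% and stands highest of the two; compound 2 gives 45%, a gap to compound 1 that lies beyond the scatter. The two differ in more than one place, so no single step can be read from them.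

Compound 3 `COc1cc(/C=C/C(=O)/C=C/c2cccs2)ccc1OCc1cn(CCCOc2cc(=O)oc3ccccc23)nn1` keeps the coumarin-linked triazole and the methoxy-bearing core of compound 1 and changes only the far aryl group: thiophen-2-yl in place of naphthalen-1-yl on a double-bonded chain carbon bound to a double-bonded chain carbon. Two six-membered aromatic rings of carbon only give way to one five-membered aromatic ring with 1 hetero atom.

Among the compounds with values here, no measured pair isolates this change, so its size is a guess. A moderate fall is expected, since the shared core and linker of compound 1 are retained; the step of a number 11 percentage points lower from compound 1 to compound 3 (beyond the scatter) is the estimate. For compound 3, a value of 55% is expected, within 35% to 75%.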

Compound 3, percent growth inhibition at one concentration: 58%
Beside the measured number, compound 3's estimate is 3 percentage points below it; measured number inside the range.
By their numbers in this assay, from the lowest: compound 2; then compounds 3 and 1 (each within the scatter of the next).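

In this assay, within the data shown here, the step of a number 8 percentage points lower from compound 1 to compound 3 (within the scatter) is the first reading of a change at a single place, with thiophen-2-yl in place of naphthalen-1-yl on a double-bonded chain carbon bound to a double-bonded chain carbon. This position therefore accepts a much smaller aryl group, going from 10 heavy atoms in two six-membered aromatic rings of carbon only to 5 heavy atoms in one five-membered aromatic ring with 1 hetero atom, without a change that stands clear of the scatter at the single concentration tested. Nothing at hand explains this outcome.

Among these compounds, compound 2 differs from compound 1 and compound 3 in more than one place, so no step to it can be read, and the separate contributions of its chain and its aryl terminus stay unresolved. Also open, going by these compounds, is whether the same position would keep its number with a non-aromatic terminus such as cyclohexyl, or with a phenyl ring carrying a carboxylic acid or an amine.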